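This account rests on a few compounds, and the source may have more. Where it says the series, first, only, none or still open, it means among the compounds named here.

Measured so far:
Compound 1, `CCOC(=O)N1CCC(=NNC(=O)c2ccc(Cl)cc2)CC1`, in a toxicity assay on BJ cells (Homo sapiens) for cytotoxicity, read by MTT assay, with a stated time of 24 h (on this read-out lower numbers stand for stronger inhibition and higher numbers for weaker inhibition), gives > 400000 nM, which is a limit of the assay rather than a number.
Compound 2, `CCOC(=O)N1CCC(=NNC(=O)c2ccc(C(F)(F)F)cc2)CC1`, in this assay gives > 400000 nM, likewise a limit of the assay and not a number.

Going by the values given here, the single measured step, a step that the two limits leave unreadable from compound 1 to compound 2, therefore has no readable size, because both of its ends sit at the limit of > 400000 nM in this assay, at which 2 of the 2 values shown sit. Where compound 2 stands can only be given as that limit; the same holds for compound 1, so no ordering between the two can be stated. Compound 3, `CCOC(=O)N1CCC(=NNC(=O)c2ccc([N+](=O)[O-])cc2)CC1`, has not yet been measured in this assay. The change from compound 2 to compound 3 is nitro in place of trifluoromethyl on an aromatic carbon. Among the compounds with values here, no measured step bears on this change with a readable size, since the step from compound 1 to compound 2 offers only a limit at either end. There is thus no ground to expect a shift beyond the scatter in either direction, and compound 3 is expected to sit at the same limit. The expected step is a step that the limit leaves unreadable from compound 2 to compound 3. The estimate for compound 3 is 500000 nM, with a range from 100000 nM to 2000000 nM.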

Compound 3, half-maximal inhibitory concentration: > 400000 nM
Compound 3: no number, only a limit (the forecaster's own chance of this, stated with the estimate: 85%); the middle value does not contradict the limit.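

Compound 3 gives > 400000 nM, a limit of the assay and not a number. The steps from compound 1 and from compound 2 to compound 3 cannot be read, because all three compounds share one limit: the limit of > 400000 nM in this assay, at which 3 of the 3 values shown sit. The compounds shown leave open whether chloro, trifluoromethyl and nitro differ at all in this assay.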